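A few compounds are considered here, and "the series" means these few. Any claim that something is new, unique, unknown or untested is made for them only; others in the source may bear on it.

Of the compounds shown here, two have been measured. Compound 1 `CC(O)(C[S+]([O-])c1ccc(C(F)(F)F)cn1)C(=O)Nc1ccc([N+](=O)[O-])cc1C(F)(F)F` was tested in a functional assay on DU-145 cells (Homo sapiens) for antiproliferative activity; a lower number here means a stronger inhibitor, a higher number a weaker inhibitor. In this assay compound 1 gives > 100000 nM; > 100000 nM (2 entries). Compound 2 `CC(O)(C[S+]([O-])c1ccc(F)cc1F)C(=O)Nc1ccc([N+](=O)[O-])cc1C(F)(F)F` is the second. In this assay compound 2 likewise gives only a limit, > 100000 nM, so no number places it on a scale. Both measured compounds sit at the boundary where (the limit of > 100000 nM in this assay, at which 1 of the 2 values shown sits), and that is all they show. Compound 3 `CC(O)(C[S+]([O-])c1ccc(C(F)(F)F)cc1)C(=O)Nc1ccc([N+](=O)[O-])cc1C(F)(F)F` differs from compound 2 in one place: 4-(trifluoromethyl)phenyl in place of 2,4-difluorophenyl on a sulfur. Among the compounds with values here, no step between two measured compounds is available, so its size can only be guessed. With both measured compounds at the limit, the step of a number no higher from compound 2 to compound 3 (the limit leaves the size open) is expected to be none beyond the scatter. Compound 3 is therefore expected to give about 100000 nM in this assay, within a range from 30000 nM to 300000 nM, most likely once more only as a limit.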

Compound 3, half-maximal inhibitory concentration: 36500 nM
The estimate for compound 3 lay 2.7-fold (0.44 log units) above the measured number; the range from low to high includes it.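

Swapping 2,4-difluorophenyl for 4-(trifluoromethyl)phenyl on the sulfur gives an at least 2.7-fold lower number from compound 2 to compound 3 (0.43 log units; beyond the scatter) in this assay. Within the data shown here, this shows that the group on the sulfur can shift the result in this assay, which the earlier compounds could not show, and compound 3 gives the first actual number of the series, 36500 nM. Compound 2 has only a limit rather than a number, so the step has a minimum size but no known full size: the limit of > 100000 nM in this assay, at which 1 of the 3 values shown sits.

The change removes two fluorines and adds a trifluoromethyl group in a single move, so the compounds shown cannot tell which part of it matters. On these data alone, it also remains open whether a nitrile, a methoxy group or an amine in place of the trifluoromethyl would lower the number further.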